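Moving the Chlorine on a Chain-Extended Analogue

The source may report more compounds than this note shows. Statements on the series, on what has been measured and on what is new or still open speak of the compounds shown alone.

Compound 2 `Cn1c(=O)c2c(nc(SCCCc3ccc(Cl)cc3)n2C)n(C)c1=O` shows, in an assay on microsomes for inhibition of Amine oxidase [flavin-containing] B (Homo sapiens), read by fluorescence and spectrophotometry, with a stated time of 20 min (on this read-out higher numbers stand for weaker inhibition and lower numbers for stronger inhibition), a value of 61 nM, the highest of the two numbers measured. Its nearest neighbour is compound 1 `Cn1c(=O)c2c(nc(SCCc3ccc(Br)cc3)n2C)n(C)c1=O`, which in this assay gives 19 nM; the step of a 3.2-fold higher number from compound 1 to compound 2 (0.51 log units; beyond the scatter) combines a change of halogen with a change of chain length, so it does not isolate either one. Compound 3 `Cn1c(=O)c2c(nc(SCCCc3cccc(Cl)c3)n2C)n(C)c1=O` differs from compound 2 by 3-chlorophenyl in place of 4-chlorophenyl on a saturated chain carbon, three bonds along the chain from a sulfur. Going by the values given here, no measured step moves a chlorine around the ring, so nothing among the measured pairs bears directly on this change, and the single known step gives no guide to its direction. The expectation is therefore a step of no change at the digits printed from compound 2 to compound 3 (within the scatter) in this assay, which lies within the scatter. Compound 3 is accordingly estimated at 61 nM, with a range from 20 nM to 200 nM.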

Compound 3, half-maximal inhibitory concentration in the Amine oxidase [flavin-containing] B assay: 62 nM
Compound 3: middle estimate off by 1.0-fold (0.01 log units), on the low side; low and high end bracket the measured number.
By their numbers in the Amine oxidase [flavin-containing] B assay, from the lowest: compound 1; then compounds 2 and 3 (each within the scatter of the next).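

In the Amine oxidase [flavin-containing] B assay, compound 2 gives 61 nM and compound 3 gives 62 nM, so putting 3-chlorophenyl in place of 4-chlorophenyl on a saturated chain carbon, three bonds along the chain from a sulfur, gives (a 1.0-fold higher number from compound 2 to compound 3 (0.01 log units; within the scatter)), and on this chain the two chlorophenyl groups cannot be told apart. In a physicochemical assay for lipophilicity, using the shake flask method, measured as octanol-water partition (on this read-out lower numbers stand for lower lipophilicity and higher numbers for higher lipophilicity), compound 2 gives 3.59 and compound 3 gives 3.76, and the same change gives (a number 0.17 log units higher from compound 2 to compound 3 (within the scatter)), so that read-out does not separate them either. Back in the Amine oxidase [flavin-containing] B assay, the step (a 3.3-fold higher number from compound 1 to compound 3 (0.51 log units; beyond the scatter)) again combines a change of halogen with a change of chain length, and so isolates neither one.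

Still open, from the compounds shown here alone, is how much of that step belongs to the halogen and how much to the chain, and whether a longer chain, or an amine in place of the chlorine, would leave the number where it stands. Nothing supplied explains why the two chlorophenyl groups give matching numbers.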